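Bromo in Place of Nitro on the Shared Core

A few compounds are considered here, and "the series" means these few. Any claim that something is new, unique, unknown or untested is made for them only; others in the source may bear on it.

In a toxicity assay on THP-1 cells (Homo sapiens) for inhibition (a higher number here means that more compound is tolerated, a lower number that less compound is tolerated), compound 1, `COc1ccc(-c2cnc(NC(=O)c3ccc([N+](=O)[O-])cc3)n2C)cc1`, gives only a limit, > 100000 nM. Compound 2, `COc1cccc(-c2cnc(NC(=O)c3ccc(F)cc3)n2C)c1`, likewise reaches only a limit, > 100000 nM, in this assay. Compound 3, `Cc1ccc(C(=O)Nc2ncc(-c3ccccc3)o2)cc1`, gives 26000 nM in this assay. Two of the three values shown sit at the limit of > 100000 nM in this assay, at which 2 of the 3 values shown sit, and compound 1 stands there, with no number of its own. For the measured compounds named here, no step between measured compounds that differ in a single place is available. Compound 4, `COc1ccc(-c2cnc(NC(=O)c3ccc(Br)cc3)n2C)cc1`, differs from compound 1 by bromo in place of nitro on an aromatic carbon. Going by the values given here, with no measured step to draw on, the expected step is an at least 1.1-fold lower number from compound 1 to compound 4 (0.04 log units; that floor lies within the scatter), small and within the scatter, with no clear direction. Compound 4 is therefore estimated to give about 90000 nM in this assay, in a range from 30000 nM to 200000 nM.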

Compound 4, half-maximal cytotoxic concentration: > 100000 nM
Compound 4 was reported as a limit; the forecaster's own chance of this, stated with the estimate: 55%; middle value at least 1.1-fold (0.04 log units) from the limit.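

For the compounds shown here, compound 1 and compound 4 both give only a limit in this assay, so no step between them can be read: the limit of > 100000 nM in this assay, at which 3 of the 4 values shown sit. The compounds shown leave open whether bromo in place of nitro on the shared core changes the tolerated concentration at all.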